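The source may report more compounds than this note shows. Statements on the series, on what has been measured and on what is new or still open speak of the compounds shown alone.

The measured compounds:

Compound 1, `COc1ccc(CSc2nnc(-c3cc([N+](=O)[O-])cc([N+](=O)[O-])c3)n2C)cc1`: in an ADME assay on A-431 cells (Homo sapiens) for cytotoxicity, with a stated time of 48 h (a higher number here means a weaker inhibitor, a lower number a stronger inhibitor), compound 1 gives > 30000 nM, a limit of the assay and not a number.
Compound 2, `CCCSc1nnc(-c2cc([N+](=O)[O-])cc([N+](=O)[O-])c2)n1Cc1ccccc1`: in this assay compound 2 gives > 30000 nM, again a limit of the assay and not a number.

Compound 2 therefore stands at the top of what the assay reports, with no number of its own. Within the data shown here, both values shown sit at the limit of > 30000 nM in this assay, at which 2 of the 2 values shown sit, so no measured step between compounds exists and nothing indicates a direction of change.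

Compound 3, `O=[N+]([O-])c1cc(-c2nnc(SCc3ccc(Cl)cc3)n2Cc2ccccc2)cc([N+](=O)[O-])c1`, has not been measured. It differs from compound 2 by 4-chlorophenyl in place of ethyl on a saturated chain carbon bound to a sulfur. With every measured value at a limit, the expected step is a step that the limit leaves unreadable from compound 2 to compound 3, meaning none beyond the scatter, and a limit is again the most likely report. Compound 3 is expected to give about 40000 nM in this assay, with a range from 15000 nM to 100000 nM.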

Compound 3, half-maximal inhibitory concentration: > 30000 nM
Compound 3 ended at the assay's limit (the forecaster's own chance of this, stated with the estimate: 80%); the middle value lies beyond the limit too.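

Compound 3 gives > 30000 nM in this assay, a limit of the assay and not a number, so no step can be read between compound 2 and compound 3: the limit of > 30000 nM in this assay, at which 3 of the 3 values shown sit.

The compounds shown leave open whether any change to these structures would bring a measurable value in this assay.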